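A Nitrile Replaces the Methyl on the Benzyl Arm

The source may report more compounds than this note shows. Statements on the series, on what has been measured and on what is new or still open speak of the compounds shown alone.

Three ethers built on one shared core were measured. Compound 1 `Cc1ccccc1Cn1cc(COc2ccc3c(=O)ccoc3c2)nn1` carries a 2-methylphenyl group on a saturated chain carbon bound to an aromatic nitrogen. In a functional assay on QGY7701 cells (Homo sapiens) for cytotoxicity, read by MTT assay, with a stated time of 48 h (on this read-out lower numbers stand for stronger inhibition and higher numbers for weaker inhibition), compound 1 reaches only > 100000 nM, which is a limit of the assay and not a number; it is the limit of > 100000 nM in this assay, at which 1 of the 3 values shown sits. Compound 2 `O=c1ccoc2cc(OCc3cn(Cc4ccc(Cl)cc4Cl)nn3)ccc12` gives 13300 nM in this assay, and compound 3 `O=c1ccoc2cc(OCc3cn(Cc4ccc(Br)cc4)nn3)ccc12` gives 96400 nM. Of the measured steps, an at least 7.5-fold lower number from compound 1 to compound 2 (0.87 log units; beyond the scatter) is the one clear gain, whereas an at least 1.0-fold lower number from compound 1 to compound 3 (0.01 log units; that floor lies within the scatter) has a floor inside the scatter, and a 7.2-fold higher number from compound 2 to compound 3 (0.86 log units; beyond the scatter) sets the two halogenated aryl groups apart.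

Compound 4 `N#Cc1ccc(Cn2cc(COc3ccc4c(=O)ccoc4c3)nn2)cc1` brings (4-cyanophenyl in place of 2-methylphenyl on a saturated chain carbon bound to an aromatic nitrogen). Its nearest measured relative by name is the 4-bromophenyl of compound 3, so the guiding step is an at least 1.0-fold lower number from compound 1 to compound 3 (0.01 log units; that floor lies within the scatter), which gave no shift beyond the scatter. Compound 4 is therefore expected to land at an estimated 85000 nM, within a range of 25000 nM to 200000 nM. The estimated step of an at least 1.1-fold lower number from compound 1 to compound 4 (0.07 log units; that floor lies within the scatter) is expected to stay inside the scatter.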

Compound 4, half-maximal inhibitory concentration: > 100000 nM
Compound 4: only a limit was reported (the forecaster's own chance of this, stated with the estimate: 40%); middle value at least 1.1-fold (0.07 log units) from the limit.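

In this assay compound 4 gives > 100000 nM, which is a limit of the assay and not a number. Its step from compound 1, also a limit, cannot be read, and an at least 1.0-fold higher number from compound 3 to compound 4 (0.01 log units; that floor lies within the scatter) has a floor within the scatter, so cyano in place of bromo on an aromatic carbon shows no readable change. By contrast, an at least 7.5-fold higher number from compound 2 to compound 4 (0.87 log units; beyond the scatter), which leaves the 2,4-dichlorophenyl of compound 2 as the only aryl group here clear of the other three, while the limit now holds more of the series: the limit of > 100000 nM in this assay, at which 2 of the 4 values shown sit.

From the compounds shown here alone, whether a 4-aminophenyl or a 4-carboxyphenyl group on a saturated chain carbon bound to an aromatic nitrogen would read clear of the limit stays open. The compounds shown also leave open which of the two chlorine atoms of compound 2 carries its gain, or whether both are needed.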